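The source may report more compounds than this note shows. Statements on the series, on what has been measured and on what is new or still open speak of the compounds shown alone.

Measured so far:
compound 1, `C=C(C)C(=O)Nc1cc2c(N3CCc4ccccc43)ncnc2cc1OC`, 4830 nM in a functional assay on PC-3 cells (Homo sapiens) for antiproliferative activity, read by MTT assay, with a stated time of 72 h; on this read-out higher numbers stand for weaker inhibition and lower numbers for stronger inhibition;
compound 2, `CC/C=C/C(=O)Nc1cc2c(N3CCc4ccccc43)ncnc2cc1OC`, 5890 nM in this assay.

Compound 2 has the higher of the two numbers, but the step of a 1.2-fold higher number from compound 1 to compound 2 (0.09 log units; within the scatter) lies within the scatter, so the two compounds cannot be ranked against each other. Compound 3, `COc1cc2ncnc(N3CCc4ccccc43)c2cc1NC(=O)/C=C/CN(C)C`, keeps the shared core and the amide and differs from compound 2 only in the chain on the carbonyl: dimethylamino in place of methyl on a saturated chain carbon bound to a double-bonded chain carbon, so that but-1-en-1-yl becomes 3-(dimethylamino)prop-1-en-1-yl. Going by the values given here, the single measured step, a 1.2-fold higher number from compound 1 to compound 2 (0.09 log units; within the scatter), also changed the chain on the carbonyl and moved nothing beyond the scatter, which is the only guide here; no step introducing a dimethylamino group has been measured. Compound 3 is therefore expected to stay close to compound 2, at an estimated 4000 nM in this assay, within about 1200 nM to 13000 nM. This corresponds to an expected step of a 1.5-fold lower number from compound 2 to compound 3 (0.17 log units; within the scatter).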

Compound 3, half-maximal inhibitory concentration: 2190 nM
Compound 3: middle estimate off by 1.8-fold (0.26 log units), on the high side; measured number inside the range.
By their numbers in this assay, from the lowest: compound 3; then compounds 1 and 2 (each within the scatter of the next).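

In this assay, the chain on the carbonyl now proves able to move the number beyond the scatter, which the earlier change at this place did not do. Dimethylamino in place of methyl on a saturated chain carbon bound to a double-bonded chain carbon gives a 2.7-fold lower number from compound 2 to compound 3 (0.43 log units; beyond the scatter) as a modest but readable gain in inhibition, and 3-(dimethylamino)prop-1-en-1-yl in place of 1-methylethenyl gives a 2.2-fold lower number from compound 1 to compound 3 (0.34 log units; beyond the scatter) in the same direction. No measurement at hand explains why this change lowers the number.

The compounds shown leave open whether a group of similar size without nitrogen, such as isopropyl, would give the same step. They also leave open how a different amine at this place, such as piperidine or morpholine, or a longer chain carrying the dimethylamino group would compare.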